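The compounds below may be only part of what the source reports. "The series", "measured", "known", "first", "only" and "open" are said of these compounds alone.

Measured so far:
compound 1 `COc1ccccc1/C=C/C(=O)c1ccc(OCC(=O)N[C@H]2CCOC2=O)cc1`: > 64000 nM
compound 2 `O=C(CNc1ccccc1)N[C@H]1CCOC1=O`: > 64000 nM

Both values come from a functional assay on MCF7 cells (Homo sapiens) for antiproliferative activity, read by MTT assay, with a stated time of 72 h; on this read-out higher numbers stand for weaker inhibition and lower numbers for stronger inhibition. For compound 1 the value > 64000 nM is a limit of the assay rather than a number. For compound 2 the value > 64000 nM is likewise a limit. On the numbers shown, compound 1 therefore stands at the limit of > 64000 nM in this assay, at which 2 of the 2 values shown sit, and nothing here separates it from compound 2. Going by the values given here, no step between two measured compounds is available, so no measured change in this assay can be used as a yardstick.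

The next compound, compound 3 `O=C(COc1ccc(C(=O)/C=C/c2cccc(Cl)c2)cc1)N[C@H]1CCOC1=O`, has not yet been measured in this assay. It differs from compound 1 in one place: 3-chlorophenyl in place of 2-methoxyphenyl on a double-bonded chain carbon bound to a double-bonded chain carbon. Since compound 1 stands at the limit of > 64000 nM in this assay, at which 2 of the 2 values shown sit, the shift expected in this assay is small, most likely none beyond the scatter, and a move toward stronger inhibition would have to be large before it showed as a number at all. Compound 3 is expected to give about 50000 nM, within a range from 10000 nM to 120000 nM. The step this estimate means is an at least 1.2-fold lower number from compound 1 to compound 3 (0.10 log units; that floor lies within the scatter).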

Compound 3, half-maximal inhibitory concentration: 20900 nM
Compound 3: the middle estimate sits 2.4-fold (0.38 log units) above what was measured; measured number inside the range.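

In this assay, going by these compounds alone, compound 3 gives 20900 nM, a real number rather than a limit, which makes it the only compound of the three with a measured value. This shows that the group on a double-bonded chain carbon bound to a double-bonded chain carbon can change the read-out even when the rest of the molecule stays the same: putting 3-chlorophenyl in place of 2-methoxyphenyl there gives an at least 3.0-fold lower number from compound 1 to compound 3 (0.48 log units; beyond the scatter). The full size of this step stays unknown because compound 1 gives only a limit of the assay: the limit of > 64000 nM in this assay, at which 2 of the 3 values shown sit.

The swap changes both the group carried on the phenyl ring and where that group sits, so the compounds shown cannot tell which of the two matters, or whether removing the methoxy or adding the chlorine does the work. They also leave open how a plain unsubstituted phenyl, or a phenyl ring carrying a nitrile or an amine, would read out at this same place on the shared core.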